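A few compounds are considered here, and "the series" means these few. Any claim that something is new, unique, unknown or untested is made for them only; others in the source may bear on it.

Measured compounds:
- Compound 1, `COc1cc(OC)c(OC)cc1/C=C/COC(=O)/C=C/c1ccc(OC)c(OC)c1`: in a functional assay on the whole organism (strain Kunming) with Mus musculus as the target, with a stated time of 0.5 h, at a dose of 300 mg/kg by the intraperitoneal route (on this read-out higher numbers stand for a weaker effect at the one dose given and lower numbers for a stronger effect), compound 1 gives 100%.
- Compound 2, `COc1ccccc1/C=C/C(=O)OC/C=C/c1cc(OC)c(OC)cc1OC`: in this assay compound 2 gives 100%.
- Compound 3, `COc1cc(OC)c(OC)cc1/C=C/COC(=O)/C=C/c1cccc(Br)c1`: in this assay compound 3 gives 100%.

Compound 3 stands level with compounds 1 and 2 in this assay. Every measured step is within the scatter: no change at the digits printed from compound 1 to compound 3 (within the scatter), no change at the digits printed from compound 2 to compound 3 (within the scatter) and no change at the digits printed from compound 1 to compound 2 (within the scatter). All three steps exchange the aryl group on a double-bonded chain carbon bound to a double-bonded chain carbon while the rest of the molecule is kept; whether the aryl carries two methoxy groups, one methoxy group or a bromine, the read-out stays at the same level.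

Compound 4, `COc1cc(OC)c(OC)cc1/C=C/COC(=O)/C=C/c1ccc(Cl)cc1`, is not yet measured. It differs from compound 3 as follows: 4-chlorophenyl in place of 3-bromophenyl on a double-bonded chain carbon bound to a double-bonded chain carbon

The three measured steps bear directly on this change, since they alter the same aryl group at the same place, and none of them moved the read-out beyond the scatter. No step beyond the scatter is therefore expected from compound 3 to compound 4: no change at the digits printed from compound 3 to compound 4 (within the scatter). Compound 4 is expected to give 100%, with a range of 85% to 100%.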

Compound 4, a percentage reported as activity, at one dose (the size of the read-out at that dose, not a potency): 100%
The estimate for compound 4 equals the measured number at the digits printed; the measured number falls inside the stated range.
By their numbers in this assay, from the lowest: compounds 1, 2, 3 and 4 (each within the scatter of the next).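

In this assay the exchange of 3-bromophenyl for 4-chlorophenyl on a double-bonded chain carbon bound to a double-bonded chain carbon gives no change at the digits printed from compound 3 to compound 4 (within the scatter) and adds a chlorine-bearing aryl group to the bromine- and methoxy-bearing ones at this place. The comparison with the methoxy-bearing aryl groups reads the same, with no change at the digits printed from compound 2 to compound 4 (within the scatter) and no change at the digits printed from compound 1 to compound 4 (within the scatter) at this place. No measurement at hand offers an explanation for this flat read-out.

With all four compounds at one level, the series does not show which group at this place, if any, would move the read-out. Open, on these data alone, are an aryl group carrying an amine or a carboxylic acid, and a longer chain between this aryl group and the ester.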